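The source may hold more compounds than are shown below. What is called first, only, known or untested is meant among the compounds shown, and "the series" means these compounds.

Compound 1, `COc1ccccc1N1CCN(CCC(=O)NCc2ccccc2-c2ccccc2)CC1`, and compound 2, `COc1ccccc1N1CCN(CCCCC(=O)NCc2ccccc2-c2ccccc2C)CC1`, were both tested in an assay on CHO-K1 cells for displacement of a labelled ligand from 5-hydroxytryptamine receptor 7 (Homo sapiens), read by scintillation counting; a lower number here means a stronger inhibitor, a higher number a weaker inhibitor. In this assay compound 1 gives 187 nM, while compound 2 gives 26.1 nM. Of these two values, that of compound 2 is the lower, and the gap to compound 1 lies beyond the usual scatter of the measurement, so compound 2 stands as the stronger inhibitor of the pair.

Compound 3, `COc1ccccc1N1CCN(CCCCC(=O)NCc2ccccc2-c2cccc(C)c2)CC1`, is built from compound 2 by a single change: 3-methylphenyl in place of 2-methylphenyl on an aromatic carbon. The two compounds contain the same atoms, joined differently. Within the data shown here, no measured pair in this set shows what such a move of a methyl group does, so the direction is open. The step from compound 2 to compound 3 is expected to be small, a 1.5-fold higher number from compound 2 to compound 3 (0.19 log units; within the scatter), likely within or only slightly beyond the scatter. In this assay compound 3 is therefore expected to give about 40 nM, with a plausible range from 15 nM to 110 nM.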

Compound 3, inhibition constant: 47.6 nM
Compound 3: middle estimate off by 1.2-fold (0.08 log units), on the low side, within the range that was stated.
By their numbers in this assay, from the lowest: compounds 2 and 3 (each within the scatter of the next); then compound 1.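

Placing the methyl group differently on this aromatic ring, with 3-methylphenyl in place of 2-methylphenyl, gives in this assay a 1.8-fold higher number from compound 2 to compound 3 (0.26 log units; within the scatter) and so leaves compound 2 and compound 3 indistinguishable in this measurement. This is the first pair shown that differs in only one place, and it indicates that both placements of the methyl group are compatible with binding values in the same range. Nothing available explains this result.

What the compounds shown leave open is how a 4-methylphenyl group, a plain phenyl group or a methoxy group would read at this place on the longer chain. Compound 1 differs from compound 2 in both the chain and the methyl group, so that comparison cannot be read for either change alone.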